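Changing the Side Chain of Compound 3

The source may hold more compounds than are shown below. What is called first, only, known or untested is meant among the compounds shown, and "the series" means these compounds.

Three compounds sharing one core have been measured in a functional assay on the whole organism (Tail, strain ICR) with Mus musculus as the target, in the tail flick test, with a stated time of 90 min, at a dose of 25 umol/kg by the oral route; a higher number here means a stronger effect of the compound at the dose given, a lower number a weaker effect:

Compound 1 `CC(C)[C@H](NC(=O)CN(c1nc(Cl)nc2[nH]cnc12)C1CC1)C(=O)OCc1ccccc1`: 51.3%
Compound 2 `C[C@@H](O)[C@H](NC(=O)CN(c1nc(Cl)nc2[nH]cnc12)C1CC1)C(=O)OCc1ccccc1`: 29.9%
Compound 3 `O=C(CN(c1nc(Cl)nc2[nH]cnc12)C1CC1)N[C@@H](CC(=O)OCc1ccccc1)C(=O)OCc1ccccc1`: 15.6%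

Compound 3 stands lowest of the three, with the step of a number 14.3 percentage points lower from compound 2 to compound 3 (beyond the scatter) and the step of a number 35.7 percentage points lower from compound 1 to compound 3 (beyond the scatter) both beyond the scatter. The compounds differ only in the group on the saturated chain carbon bound to the amide-type nitrogen and the carbonyl carbon, and compound 3, carrying the (benzyloxycarbonyl)methyl group, sits at the bottom.

Compound 4 `NC(=O)CC[C@H](NC(=O)CN(c1nc(Cl)nc2[nH]cnc12)C1CC1)C(=O)OCc1ccccc1` is not yet measured. It differs from compound 3 as follows: carbamoylmethyl in place of benzyloxycarbonyl on a saturated chain carbon, two bonds along the chain from an amide-type nitrogen and a carbonyl carbon. Among the measured compounds shown here, no measured step involves a carbamoylmethyl group, so the closest guide is indirect. The step of a number 21.4 percentage points lower from compound 1 to compound 2 (beyond the scatter) shows that a side chain bearing a hydrogen-bond donor sits lower than isopropyl yet higher than compound 3, and the step of a number 14.3 percentage points lower from compound 2 to compound 3 (beyond the scatter) shows that the benzyloxycarbonyl-bearing side chain of compound 3 scores lower still. Removing the benzyloxycarbonyl is therefore expected to move compound 4 upward only modestly in this assay. The estimated step is a number 9.4 percentage points higher from compound 3 to compound 4 (within the scatter). Compound 4 is estimated at 25%, with a likely range from 10% to 45%.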

Compound 4, a percentage reported as activity, at one dose (the size of the read-out at that dose, not a potency): 42.8%
The estimate for compound 4 lay 17.8 percentage points below the measured number, within the range that was stated.
By their numbers in this assay, from the lowest: compound 3; then compound 2; then compounds 4 and 1 (each within the scatter of the next).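

The three earlier compounds all sat lower as the isopropyl group gave way to larger or oxygen-bearing side chains, but the 2-carbamoylethyl group of compound 4 breaks that trend in this assay: the step is a number 8.5 percentage points lower from compound 1 to compound 4 (within the scatter), so this group and isopropyl cannot be told apart here. The position therefore accepts a side chain with a hydrogen-bond donor, although having a donor does not settle the outcome, as compound 2 also carries one and the step is a number 12.9 percentage points higher from compound 2 to compound 4 (beyond the scatter). The change from (benzyloxycarbonyl)methyl to 2-carbamoylethyl also gives a number 27.2 percentage points higher from compound 3 to compound 4 (beyond the scatter), showing that this side chain has a clear influence on the read-out, although nothing shown explains why the numbers move this way.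

Compounds 3 and 4 differ in both the length of the side chain and the group at its end, so the contribution of each remains unresolved. A 2-(benzyloxycarbonyl)ethyl chain would keep the ester of compound 3 on the chain length of compound 4, while a 2-carboxyethyl chain, ending in a carboxylic acid, or a chain ending in an amine would test other end groups at that length.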